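Oral exposure in rat for three ester analogs

This account rests on a few compounds, and the source may have more. Where it says the series, first, only, none or still open, it means among the compounds named here.

Measured in an ADME assay on the whole organism (plasma, strain Fischer) for pharmacokinetics, with Rattus norvegicus as the target, at a dose of 30 mg/kg by the oral route; a lower number here means less compound in the circulation, a higher number more compound in the circulation at the dose given:
compound 1 `CCOC(=O)c1ccc(Cl)cc1O[C@H]1CC[C@H]2CN[C@H](C(=O)OCC)C[C@H]2C1` — 9190 ng.h/mL
compound 2 `CCOC(=O)c1ccc(-c2ccccc2)cc1O[C@H]1CC[C@H]2CN[C@H](C(=O)OCC)C[C@H]2C1` — 7230 ng.h/mL
compound 3 `CCOC(=O)c1ccccc1S[C@H]1CC[C@H]2CN[C@H](C(=O)OCC)C[C@H]2C1` — 7530 ng.h/mL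

Compound 2 sits within the scatter of both other numbers: its gap to compound 3 and its gap to compound 1 are each too small to call a difference, so the three values are effectively one level. Within the data shown here, the only step between measured compounds is a 1.3-fold lower number from compound 1 to compound 2 (0.10 log units; within the scatter), a change at the same aromatic carbon that did not move the number beyond the scatter.

Compound 4 `CCOC(=O)c1ccccc1O[C@H]1CC[C@H]2CN[C@H](C(=O)OCC)C[C@H]2C1` differs from compound 2 at that carbon: hydrogen in place of phenyl on an aromatic carbon. Compound 3 also carries hydrogen there and gives 7530 ng.h/mL. On these numbers no step beyond the scatter is expected, a 1.1-fold higher number from compound 2 to compound 4 (0.04 log units; within the scatter). Compound 4 is therefore estimated at 8000 ng.h/mL, with a range from 4000 ng.h/mL to 16000 ng.h/mL.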

Compound 4, area under the concentration-time curve: 24700 ng.h/mL
Estimate against measurement, compound 4: 3.1-fold (0.49 log units) below, and the stated range ends below it.
By their numbers in this assay, from the lowest: compounds 2, 3 and 1 (each within the scatter of the next); then compound 4.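

In this assay the aromatic carbon para to the ethoxycarbonyl group proves sensitive to substitution: hydrogen in place of phenyl gives a 3.4-fold higher number from compound 2 to compound 4 (0.53 log units; beyond the scatter) and hydrogen in place of chloro gives a 2.7-fold higher number from compound 1 to compound 4 (0.43 log units; beyond the scatter) even though phenyl and chloro lie within the scatter of each other. Both steps rest on compound 4 alone, so the high level is so far tied to a single compound. No measurement here accounts for this rise.

As far as these compounds go, whether any group at this carbon keeps the number at the level of compound 4 stays open. An amine or a methoxy group there would test this.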